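Moving the fluorine in the sulfanyl series

A few compounds are considered here, and "the series" means these few. Any claim that something is new, unique, unknown or untested is made for them only; others in the source may bear on it.

Measured in a functional assay on HeLa cells (Homo sapiens) for inhibition, read by CCK-8 assay, with a stated time of 72 h, tested at 2 uM; on this read-out higher numbers stand for more inhibition of growth at the one concentration tested and lower numbers for less inhibition of growth:
- compound 1 `Nc1ccccc1NC(=O)c1ccc(CSc2cccc(F)c2)cc1` gives 22.5%
- compound 2 `Nc1ccccc1NC(=O)/C=C/c1ccc(CSc2cccc3ccccc23)cc1` gives 20.6%

Only these two numbers are available so far. Compound 1 stands within the scatter of compound 2, so the two cannot be ranked. Going by the values given here, the pair differs in more than one place, so no measured step bears directly on the change considered here.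

Compound 3 `Nc1ccccc1NC(=O)c1ccc(CSc2ccc(F)cc2)cc1` keeps the core of compound 1 and alters only the group on a sulfur: 4-fluorophenyl in place of 3-fluorophenyl on a sulfur. In words, this is 4-fluorophenyl in place of 3-fluorophenyl on a sulfur, and the two compounds have the same atoms, joined differently. The data do not show how this change acts on growth inhibition. No step beyond the scatter is therefore expected in this assay, and neither direction is favoured. The starting point is compound 1 at 22.5%. The expected change is small, with an estimated a number 0.5 percentage points lower from compound 1 to compound 3 (within the scatter). For compound 3 the estimated value is 22%, with an expected range from 10% to 38%.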

Compound 3, percent growth inhibition at one concentration: 27.9%
Beside the measured number, compound 3's estimate is 5.9 percentage points below it, within the range that was stated.
By their numbers in this assay, from the lowest: compounds 2, 1 and 3 (each within the scatter of the next).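

Going by these compounds alone, this is the first measured step at this position in the sulfanyl series: in this assay 4-fluorophenyl in place of 3-fluorophenyl on a sulfur gives a number 5.4 percentage points higher from compound 1 to compound 3 (within the scatter) and so does not separate the two compounds. With the same atoms joined differently, compound 1 and compound 3 cannot be ranked, and at the one concentration tested this position shows no measurable preference between the 3-fluorophenyl and 4-fluorophenyl groups. Nothing available bears on the cause of this reading.

Compound 2 differs from compound 1 and compound 3 in more than one place, so it adds nothing to this comparison, and the compounds shown do not tell whether a step beyond the scatter appears with a different group on the sulfur, such as 4-chlorophenyl, 4-methoxyphenyl or benzyl. They also leave open whether compound 1 and compound 3 would remain inseparable across a range of concentrations, since this assay gives one reading for each compound at a single concentration.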